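From Ethyl to Benzylamino on the Shared Core

The source may hold more compounds than are shown below. What is called first, only, known or untested is meant among the compounds shown, and "the series" means these compounds.

Of the compounds shown here, two have been measured so far. Compound 1 `CCc1nc(C(=O)c2ccc(C)s2)c2sccc2n1` gives 3670 nM in a functional assay on CHO-K1 cells for antagonist activity at adenosine receptor A2b (Homo sapiens), read by FLIPR and calcium flux (on this read-out higher numbers stand for weaker inhibition and lower numbers for stronger inhibition), the highest of the two numbers seen. Compound 2 `CCNc1nc(C(=O)c2ccc(C)s2)c2sccc2n1` gives 1260 nM in this assay. For the measured compounds named here, the one recorded step between them, a 2.9-fold lower number from compound 1 to compound 2 (0.46 log units; beyond the scatter), puts an ethylamino group where compound 1 carries an ethyl group and brings a modest gain in inhibition.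

Compound 3 `Cc1ccc(C(=O)c2nc(NCc3ccccc3)nc3ccsc23)s1` has not yet been measured. It differs from compound 1 as follows: benzylamino in place of ethyl on an aromatic carbon. Going by the values given here, the entering benzylamino, like the ethylamino of compound 2, is attached through an amino group, so the step from compound 1 to compound 2 is the measured step that bears on this change; no step to a benzyl-bearing compound exists. Because a 2.9-fold lower number from compound 1 to compound 2 (0.46 log units; beyond the scatter) lay beyond the scatter, a lowering of similar, possibly somewhat larger, size is expected for compound 3, a 4.1-fold lower number from compound 1 to compound 3 (0.61 log units; beyond the scatter). Compound 3 is therefore estimated at 900 nM in this assay, with a plausible range from 250 nM to 3000 nM.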

Compound 3, half-maximal inhibitory concentration: 5580 nM
Compound 3: the middle estimate sits 6.2-fold (0.79 log units) below what was measured; the measured number lies above the stated range.
By their numbers in this assay, from the lowest: compound 2; then compounds 1 and 3 (each within the scatter of the next).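

Compound 3 shows that an amino link at this aromatic carbon does not bring a gain in inhibition by itself. In this assay, benzylamino in place of ethyl gives a 1.5-fold higher number from compound 1 to compound 3 (0.18 log units; within the scatter) and so cannot be told apart from the ethyl group of compound 1 on this read-out. The sharper comparison is with compound 2, where phenyl in place of methyl on the saturated chain carbon bound to the nitrogen gives a 4.4-fold higher number from compound 2 to compound 3 (0.65 log units; beyond the scatter) and weaker inhibition, so across these three compounds the gain seen with ethylamino depends on what the nitrogen carries and is gone once the phenyl is present.

On these data alone, it remains open whether a plain amine, a methylamino group or a longer chain such as propylamino at this carbon would match or improve on the ethylamino group of compound 2, and whether a cyclohexylmethylamino or phenethylamino group would behave like benzylamino. Nothing available gives a reason for the weaker inhibition of compound 3 compared with compound 2.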